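Carbamoylcyclohexyl for methoxycyclohexylmethyl on the ring nitrogen

The source may hold more compounds than are shown below. What is called first, only, known or untested is meant among the compounds shown, and "the series" means these compounds.

Working notes on the series. In an assay on isolated protein for inhibition of protein kinase C delta type (Homo sapiens), read by TR-FRET, with a stated time of 2 h (on this read-out lower numbers stand for stronger inhibition and higher numbers for weaker inhibition), compound 3 `CO[C@H]1CC[C@H](CNc2cc(NCc3cnccc3C(F)(F)F)ncc2C#N)CC1` gives only a limit of the assay, > 10000 nM. Compound 1 `N#Cc1cnc(NCc2cnccc2C(F)(F)F)cc1NC[C@H]1C[C@H](O)C1` likewise gives only a limit, > 10000 nM. Both sit at the limit of > 10000 nM in this assay, at which 2 of the 3 values shown sit. Among the measured compounds shown here, compound 2 `N#Cc1cnc(NCc2cnccc2C(F)(F)F)cc1N[C@H]1CC[C@@H](O)CC1` gives 4500 nM, the one numerical value so far. Compound 4 `N#Cc1cnc(NCc2cnccc2C(F)(F)F)cc1N[C@H]1CC[C@@H](C(N)=O)CC1` differs from compound 3 by 4-carbamoylcyclohexyl in place of (4-methoxycyclohexyl)methyl on a nitrogen on an aromatic ring. For the measured compounds named here, two measured steps bear on it: an at least 2.2-fold lower number from compound 1 to compound 2 (0.34 log units; beyond the scatter) and an at least 2.2-fold higher number from compound 2 to compound 3 (0.34 log units; beyond the scatter), the latter running in the opposite sense to the present change, since compound 4 returns to a cyclohexyl bound directly to the nitrogen, as in compound 2. A lower number than the limit of compound 3 is therefore expected, at least modest, with the step of an at least 3.3-fold lower number from compound 3 to compound 4 (0.52 log units; beyond the scatter) as the estimate. For compound 4 the expected value is 3000 nM, in the range 800 nM to 10000 nM.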

Compound 4, half-maximal inhibitory concentration: 400 nM
Compound 4: middle estimate off by 7.5-fold (0.88 log units), on the high side; the whole stated range lies above it.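

In this assay, carbamoyl in place of hydroxy on a saturated ring carbon, with the same cyclohexyl bound directly to the nitrogen, gives a large step between two numerical values (an 11-fold lower number from compound 2 to compound 4 (1.05 log units; beyond the scatter)). Among the compounds shown here, this shows that the group on the far end of the ring changes the read-out, which the earlier compounds did not show. Against the two compounds held at a limit of the assay, the steps (an at least 25-fold lower number from compound 3 to compound 4 (1.39 log units; beyond the scatter)) and (an at least 25-fold lower number from compound 1 to compound 4 (1.39 log units; beyond the scatter)) give bounds only: the limit of > 10000 nM in this assay, at which 2 of the 4 values shown sit.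

Open, as far as these compounds go, is whether a carboxylic acid, a methyl amide or an amine on the same ring carbon would keep the number of compound 4.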